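Hydrogen in Place of Benzyl on the Ring Nitrogen

The compounds below may be only part of what the source reports. "The series", "measured", "known", "first", "only" and "open" are said of these compounds alone.

Of the compounds shown here, three sharing one core have been tested in a functional assay on A549 cells (Homo sapiens) for antiproliferative activity, read by MTT assay, with a stated time of 48 h; on this read-out higher numbers stand for weaker inhibition and lower numbers for stronger inhibition. Compound 1 `CCOC(=O)CNc1nc(Nc2ccccc2)ncc1[N+](=O)[O-]` carries hydrogen on the nitrogen that bears the ester chain and an unsubstituted phenyl on the other nitrogen. In this assay compound 1 gives > 100000 nM, which is a limit of the assay and not a number. Compound 2 `COC(=O)CN(C)c1nc(Nc2cccc(OC)c2)ncc1[N+](=O)[O-]`, with methyl on the chain-bearing nitrogen and a methoxyphenyl, gives 31900 nM in this assay. Compound 3 `CCOC(=O)CN(Cc1ccccc1)c1nc(Nc2cccc(OC)c2)ncc1[N+](=O)[O-]` carries benzyl on that nitrogen together with the same methoxyphenyl. In this assay compound 3 gives > 100000 nM, again a limit of the assay rather than a number. Compound 3 thus stands at the limit of > 100000 nM in this assay, at which 2 of the 3 values shown sit, so its true value is not pinned down. Compound 4 `CCOC(=O)CNc1nc(Nc2cccc(OC)c2)ncc1[N+](=O)[O-]` differs from compound 3 by hydrogen in place of benzyl on a nitrogen on an aromatic ring. Compound 1, which also bears hydrogen at that nitrogen, is itself reported only as a limit. Only compound 2, with methyl there, yielded a figure. The step is therefore expected to be small, a number no higher from compound 3 to compound 4 (the limit leaves the size open), not beyond the scatter and most likely ending at the limit again. Compound 4 is estimated at 100000 nM, with a range from 30000 nM to 300000 nM.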

Compound 4, half-maximal inhibitory concentration: 36100 nM
Compound 4: middle estimate off by 2.8-fold (0.44 log units), on the high side, and the stated range covers the measured number.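

On these data alone, removing the benzyl group from the nitrogen on an aromatic ring turns a limit into a figure in this assay: hydrogen in its place gives an at least 2.7-fold lower number from compound 3 to compound 4 (0.44 log units; beyond the scatter), a step that starts from a limit of the assay, so its full size stays unknown. The methoxy group also counts when hydrogen sits on the chain-bearing nitrogen, as methoxy in place of hydrogen on an aromatic carbon gives an at least 2.7-fold lower number from compound 1 to compound 4 (0.44 log units; beyond the scatter), again a step that starts from a limit of the assay. Exchanging ((methoxycarbonyl)methyl)(methyl)amino for ((ethoxycarbonyl)methyl)amino gives a 1.1-fold higher number from compound 2 to compound 4 (0.05 log units; within the scatter), so this combined change of ester and nitrogen substituent does not separate the two compounds, while the compounds without a figure remain those at the limit: the limit of > 100000 nM in this assay, at which 2 of the 4 values shown sit.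

As far as these compounds go, the true values of compound 1 and compound 3 remain open, and so does the separate contribution of the ester and the nitrogen substituent within the combined change. From the compounds shown here alone, it is also open how an ethyl group or a longer chain on that nitrogen, or a carboxylic acid in place of the ester, would read in this assay.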